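Second aromatic methyl on two related cores

The source may report more compounds than this note shows. Statements on the series, on what has been measured and on what is new or still open speak of the compounds shown alone.

Compound 1 `COc1cc2c(cc1OC)C(=O)/C(=C/c1cccc(C)c1)CC2` gives 17000 nM in a functional assay on Jurkat cells (Homo sapiens) for antiproliferative activity, read by MTT assay; a higher number here means a weaker inhibitor, a lower number a stronger inhibitor. Compound 2 `COc1cc2c(cc1OC)C(=O)/C(=C/c1cc(C)cc(C)c1)CC2` differs by methyl in place of hydrogen on an aromatic carbon and gives 4000 nM; the step is a 4.3-fold lower number from compound 1 to compound 2 (0.63 log units; beyond the scatter). Compound 3 `COc1cc2c(cc1OC)C(=O)/C(=C/c1cccc(C)c1)C2` gives 1800 nM, the lowest of the three numbers; the difference between the cores of compound 1 and compound 3 is not broken down here. Compound 4 `COc1cc2c(cc1OC)C(=O)/C(=C/c1cc(C)ccc1C)C2` differs from compound 3 by methyl in place of hydrogen on an aromatic carbon. In compound 2 the entering methyl sits meta to a large group and meta to a methyl group, whereas in compound 4 it sits ortho to a large group and para to a methyl group, so this is the same kind of change, not the same one. Because a 4.3-fold lower number from compound 1 to compound 2 (0.63 log units; beyond the scatter) was modest, an expected step of a 2.0-fold lower number from compound 3 to compound 4 (0.30 log units; within the scatter) seems reasonable, tempered for the different surroundings. Compound 4 is estimated at 900 nM, expected between 300 nM and 2700 nM.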

Compound 4, half-maximal inhibitory concentration: 30500 nM
For compound 4 the middle estimate is 34-fold (1.53 log units) below the measured one, outside the stated range (above it).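

In this assay the methyl in place of hydrogen gives a 17-fold higher number from compound 3 to compound 4 (1.23 log units; beyond the scatter). Size and direction do not carry over from the core of compound 1 to the core of compound 3 in these two pairs: the same change on two cores in this assay, a 4.3-fold lower number (0.63 log units; beyond the scatter) from compound 1 to compound 2 and a 17-fold higher number (1.23 log units; beyond the scatter) from compound 3 to compound 4, 72-fold (1.86 log units) apart, beyond the scatter of two such steps

This does not show that the core alone decides the outcome, since the entering methyl in compound 4 sits ortho to a large group and para to a methyl group, and the placement differs from that in compound 2. The two pairs cannot separate the core from the placement.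

Open, as far as these compounds go, is how the core of compound 3 responds to a methyl placed as in compound 2. Also open, from the compounds shown here alone, is whether a fluorine or an amine at the place of the new methyl in compound 4 would follow the same course.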